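A few compounds are considered here, and "the series" means these few. Any claim that something is new, unique, unknown or untested is made for them only; others in the source may bear on it.

Working notes on the series. In a physicochemical assay for lipophilicity, measured as octanol-water partition (on this read-out lower numbers stand for lower lipophilicity and higher numbers for higher lipophilicity), compound 1 (`C#CCc1c(Cl)cc(N/C=N/OC(C)C)cc1Cl`) gives 3.9, compound 2 (`C#CCc1c(Cl)cc(N/C=N/OC/C=C\Cl)cc1Cl`) gives 3.9 and compound 3 (`C#CCc1c(Cl)cc(N/C=N/OC/C=C/Cl)cc1Cl`) gives 3.9. Compound 3 therefore stands level with the other two, and the series shows no spread so far.

The next step leads to compound 4 (`C#CCc1c(Cl)cc(N/C=N/Oc2ccccc2)cc1Cl`), with phenyl in place of 3-chloroprop-2-en-1-yl on an oxygen.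

Two measured changes concern the same oxygen. Putting 3-chloroprop-2-en-1-yl in place of isopropyl gave no change at the digits printed from compound 1 to compound 2 (within the scatter) and no change at the digits printed from compound 1 to compound 3 (within the scatter). The third step, no change at the digits printed from compound 2 to compound 3 (within the scatter), comes with the fact that compounds 2 and 3 differ only in the configuration as drawn, so it says little about a change of group.

These steps show that one exchange on this oxygen left this assay flat. None of them, however, involves an aromatic ring on the oxygen, so they are only a loose guide for phenyl. A small step is the working expectation, upward if it has any direction, and it may not clear the scatter. The expected step is a number 0.20 log units higher from compound 3 to compound 4 (within the scatter), and this remains an estimate.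

For compound 4 the estimated value is 4.1, with an expected range of 3.6 to 4.7.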

Compound 4, partition coefficient: 4.4
The estimate for compound 4 lay 0.30 log units below the measured number; measured number inside the range.
By their numbers in this assay, from the lowest: compounds 1, 2 and 3 (each within the scatter of the next); then compound 4.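

Working from this assay as the read-out, this oxygen no longer looks flat: phenyl in place of 3-chloroprop-2-en-1-yl gives a number 0.50 log units higher from compound 3 to compound 4 (beyond the scatter) and a number 0.50 log units higher from compound 2 to compound 4 (beyond the scatter) as the first steps in the series to clear the scatter. Phenyl in place of isopropyl gives a number 0.50 log units higher from compound 1 to compound 4 (beyond the scatter) as well, so the same modest rise is reached from all three earlier compounds, and compound 4, the only one here with an aromatic ring on this oxygen, stands apart from the level group formed by compounds 1, 2 and 3. The data shown give no measured basis for explaining why this exchange moves the number.

With a single aromatic group on this oxygen, the compounds shown cannot separate the presence of a ring from the larger number of heavy atoms that phenyl brings in. As far as these compounds go, how the number responds to a benzyl group, a pyridyl ring, a saturated cyclohexyl ring or a phenyl ring carrying an amine or a carboxylic acid remains open.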